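The source may report more compounds than this note shows. Statements on the series, on what has been measured and on what is new or still open speak of the compounds shown alone.

Measured so far in a physicochemical assay for lipophilicity; a lower number here means a more polar compound, a higher number a more lipophilic compound:
- compound 1 `CNC(=O)c1cc(C(=O)N[C@H]2CC[C@H](O)CC2)n([C@@H](C)c2cccc(Cl)c2)n1`: 3.7
- compound 2 `CNC(=O)c1cc(C(=O)N[C@H]2[C@@H]3C[C@@H](OC)C[C@@H]32)n([C@@H](C)c2ccccc2)n1`: 2.7
- compound 3 `CNC(=O)c1cc(C(=O)NC2CCOCC2)n([C@@H](C)c2ccccc2)n1`: 3.6

Compound 3, at 3.6, lies within the scatter of compound 1 and beyond the scatter above compound 2. Compound 4 `CNC(=O)c1cc(C(=O)N[C@H]2CC[C@H](O)CC2)n([C@@H](C)c2ccccc2)n1` is not yet measured. It has 4-hydroxycyclohexyl in place of oxan-4-yl on an amide-type nitrogen. Going by the values given here, the only measured step at that nitrogen is modest: a number 0.90 log units higher from compound 2 to compound 3 (beyond the scatter). Among the compounds with values here, compound 1 also carries 4-hydroxycyclohexyl and gives 3.7, but no measured pair isolates this change. A smaller, downward step in this assay is therefore expected, not clearly beyond the scatter. The expected change is a number 0.30 log units lower from compound 3 to compound 4 (within the scatter). For compound 4 the estimated value is 3.3, with an expected range of 2.8 to 3.7.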

Compound 4, distribution coefficient: 2.9
Beside the measured number, compound 4's estimate is 0.40 log units above it; the measured number falls inside the stated range.
By their numbers in this assay, from the lowest: compounds 2 and 4 (each within the scatter of the next); then compounds 3 and 1 (each within the scatter of the next).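

Isolated for the first time in this assay, 4-hydroxycyclohexyl in place of oxan-4-yl on an amide-type nitrogen gives a number 0.70 log units lower from compound 3 to compound 4 (beyond the scatter) as a modest step. Hydrogen in place of chloro on an aromatic carbon, also isolated now, gives a number 0.80 log units lower from compound 1 to compound 4 (beyond the scatter) as a second modest step, so the number responds to both places. The group of 8 heavy atoms on that nitrogen, replaced by 4-hydroxycyclohexyl, gives a number 0.20 log units higher from compound 2 to compound 4 (within the scatter) and no separation.

On these data alone, whether an amine or a carboxylic acid in place of the hydroxy would move this assay further stays open, as does whether the chloro step holds with oxan-4-yl on the nitrogen. Nothing measured here explains these steps.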